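The compounds below may be only part of what the source reports. "The series", "measured", "known", "first", "only" and "open" are said of these compounds alone.

In an ADME assay on WI-38 cells (Homo sapiens) for inhibition, read by CellTiter-Glo, with a stated time of 48 h, tested at 100 uM (on this read-out lower numbers stand for less inhibition and higher numbers for more inhibition at the one concentration tested (going by the name of the read-out)), compound 1 `CC(C)(C)OC(=O)/C=C\NC(=O)[C@H](O)C(C)(C)CO` gives -14%, and compound 2 `CC(C)(C)OC(=O)/C=C/NC(=O)[C@H](O)C(C)(C)CO` gives 0%, the higher of the two numbers; the step of a number 14 percentage points higher from compound 1 to compound 2 (beyond the scatter) rests on (the fact that compounds 1 and 2 differ only in the configuration as drawn). Compound 3 `CC(C)(C)OC(=O)/C=C\NC(=O)[C@@H](O)C(C)(C)CO` is the next change from compound 2: the two compounds have the same atoms and bonds and differ only in configuration as drawn: 2 of 2 stereo elements differ; a stereocentre at a saturated chain carbon is drawn R in compound 2 and S in compound 3; a double bond is drawn E in compound 2 and Z in compound 3. Among the compounds with values here, the double-bond part of that change runs opposite to the one measured step, so a fall of about that size is plausible, while the change at the stereocentre has no measured counterpart here. Compound 3 is therefore expected to show a modest drop, a number 10 percentage points lower from compound 2 to compound 3 (within the scatter), to an estimated -10% in this assay, within -30% to 10%.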

Compound 3, a percentage reported as inhibition, at one concentration (the size of the read-out at that concentration, not a potency): 26%
Estimate against measurement, compound 3: 36 percentage points below, outside the stated range (above it).
By their numbers in this assay, from the lowest: compound 1; then compound 2; then compound 3.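

In this assay the stereocentre at a saturated chain carbon now has a step of its own, with the double bond drawn Z on both sides: a number 40 percentage points higher from compound 1 to compound 3 (beyond the scatter). That step rests on configuration alone: the fact that compounds 1 and 3 differ only in the configuration as drawn. The step of a number 26 percentage points higher from compound 2 to compound 3 (beyond the scatter) changes both stereo elements at once, so it cannot be divided between them.

From the compounds shown here alone, the pairing of an E double bond with an S stereocentre stays open, and with it whether the two elements add. Also open, going by these compounds, is whether the stereocentre step survives replacing the hydroxyl with an amine or the tert-butyl ester with a carboxylic acid.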